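The compounds below may be only part of what the source reports. "The series", "measured", "known", "first", "only" and "open" are said of these compounds alone.

Compound 1 `C=CC1=C(C(=O)Nc2ccccc2)C(c2ccc(OC)cc2)OC1` gives > 100000 nM in a functional assay on HeLa cells (Homo sapiens) for cytotoxicity, read by MTT assay, with a stated time of 24 h (on this read-out higher numbers stand for weaker inhibition and lower numbers for stronger inhibition), which is a limit of the assay.
Compound 2 `C=CC1=C(C(=O)NCc2ccccc2F)C(c2ccc(OC)cc2)OC1` gives > 100000 nM in this assay, again a limit of the assay.

Compound 1 therefore stands only at a limit, and the limit of > 100000 nM in this assay, at which 2 of the 2 values shown sit, covers both values shown. The step that the two limits leave unreadable from compound 1 to compound 2 cannot be read. Compound 3 `C=CC1=C(C(=O)Nc2ccccc2)C(c2ccc(OC)c(OC)c2)OC1` differs from compound 1 by methoxy in place of hydrogen on an aromatic carbon. For the measured compounds named here, no measured step resembles this change, and the one step available gives no size. Compound 3 is expected to remain near the limit, the step that the limit leaves unreadable from compound 1 to compound 3 meaning no change beyond the scatter. Compound 3 is estimated at 150000 nM, within 40000 nM to 600000 nM.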

Compound 3, half-maximal inhibitory concentration: 5030 nM
Compound 3: middle estimate off by 30-fold (1.47 log units), on the high side, and the stated range ends above it.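

In this assay, methoxy in place of hydrogen on an aromatic carbon, ortho to a methoxy group and meta to a large group, gives an at least 19-fold lower number from compound 1 to compound 3 (1.29 log units; beyond the scatter). For the compounds shown here, this is the first readable step, and it shows that this ring position can move the read-out well beyond the scatter with a change of only 2 heavy atoms. Compound 3 alone stands clear of the limit: the limit of > 100000 nM in this assay, at which 2 of the 3 values shown sit.

As far as these compounds go, it remains open whether a hydroxyl, a chlorine or an ethoxy group at this position would do the same. From the compounds shown here alone, the effect of this methoxy group with the 2-fluorobenzyl amide of compound 2 also remains open.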